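A swapped group on the nitrogen of compound 2

A few compounds are considered here, and "the series" means these few. Any claim that something is new, unique, unknown or untested is made for them only; others in the source may bear on it.

Going by the values given here, in a functional assay on DLD-1 cells (Homo sapiens) for cytotoxicity, read by resazurin assay, with a stated time of 48 h (a higher number here means that more compound is needed for the effect, a lower number that less compound is needed), compound 2 (`COc1ccc(S(=O)(=O)Nc2ccc3oc(-c4ccc(NC(=O)c5cccc(C)c5[N+](=O)[O-])cc4)nc3c2)cc1`) gives 1500 nM, the lower of the two numbers so far. The other number comes from compound 1 (`O=S(=O)(Nc1ccc(-c2nc3cc(NS(=O)(=O)c4ccccc4Cl)ccc3o2)cc1)c1ccccc1Cl`), and compound 1 gives 17000 nM, a gap beyond the scatter. These two compounds differ in more than one place, so no single measured change offers a direct guide.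

Compound 3 (`COc1ccc(S(=O)(=O)Nc2ccc3oc(-c4ccc(NS(=O)(=O)c5cc(F)ccc5OC)cc4)nc3c2)cc1`) is compound 2 with one group exchanged: a group of 12 heavy atoms (7 carbon, 3 oxygen, 1 fluorine, 1 sulfur; one six-membered aromatic ring of carbon only) in place of a group of 12 heavy atoms (8 carbon, 1 nitrogen, 3 oxygen; one six-membered aromatic ring of carbon only), on a nitrogen on an aromatic ring. The entering group contains sulfur, as does the group at the matching place in compound 1, whose number is 17000 nM. That resemblance points upward, though only weakly. The expected change is a 3.3-fold higher number from compound 2 to compound 3 (0.52 log units; beyond the scatter), an estimated move to a higher number in this assay, beyond the scatter. For compound 3, the estimated value is 5000 nM, with an expected range from 1300 nM to 20000 nM.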

Compound 3, half-maximal effective concentration: 18000 nM
For compound 3 the middle estimate is 3.6-fold (0.56 log units) below the measured one; the measured number falls inside the stated range.
By their numbers in this assay, from the lowest: compound 2; then compounds 1 and 3 (each within the scatter of the next).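

The change at this nitrogen gives a 12-fold higher number from compound 2 to compound 3 (1.08 log units; beyond the scatter) in this assay, so this position clearly matters for the number in this assay. The size of that step stands out since the two groups match on everything counted: each has 12 heavy atoms, one six-membered aromatic ring of carbon only, 2 double bonds outside aromatic rings, 0 hydrogen-bond donors, 3 hydrogen-bond acceptors and no net charge, so what separates them lies in their atoms and how these are arranged. No measurement at hand explains the rise.

Going by these compounds, the groups differ in several parts at once, so the part that carries the step stays open: the sulfur, the fluorine, the nitrogen of the leaving group or something else. A plain benzoyl or a small acetyl group on this nitrogen could help to separate these parts.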